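The compounds below may be only part of what the source reports. "The series", "measured", "known", "first", "only" and "open" are said of these compounds alone.

Measured compounds:
- compound 1, `COc1cc(C2C(C#N)=C(N)Oc3cc(Br)ccc32)cc(Br)c1OC`: 140000000 nM
- compound 2, `COc1cc(C2C(C#N)=C(N)Oc3c2ccc(O)c3O)cc(Br)c1OC`: 589000000 nM
- compound 3, `N#CC1=C(N)Oc2c(ccc(N)c2N)C1c1cccc([N+](=O)[O-])c1`: 390000000 nM

In a functional assay on T47D cells (Homo sapiens) for activation (a lower number here means that less compound is needed, a higher number that more compound is needed for the effect), compound 1 gives 140000000 nM, the lowest number of the three. Compound 3 stands nearest to it with 390000000 nM, a gap that lies beyond the usual scatter, and compound 2 stands furthest with 589000000 nM, also beyond the scatter. Compound 1 is therefore the compound of this set that needs the least material for the effect in this assay. Compounds 2 and 3 each differ from compound 1 in more than one place, so no single change among the measured compounds can be read off.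

The next compound, compound 4, `COc1cc(C2C(C#N)=C(N)Oc3cc(N)ccc32)cc(Br)c1OC`, keeps the shared core of compound 1 and differs from it in one place: amino in place of bromo on an aromatic carbon. Within the data shown here, no measured pair shows this change on its own. The two other compounds that carry hydroxyl or amino groups on the fused ring, compound 2 with 589000000 nM and compound 3 with 390000000 nM, both give higher numbers than compound 1, but each also differs elsewhere, so they give only a loose hint. A modest step upward, of the order of the gap to compound 3, is expected for the step of a 1.8-fold higher number from compound 1 to compound 4 (0.25 log units; within the scatter), with a range wide enough to include no change beyond the scatter. For compound 4 in this assay the estimate is 250000000 nM, expected between 80000000 nM and 800000000 nM.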

Compound 4, half-maximal effective concentration: 33000000 nM
Compound 4: middle estimate off by 7.6-fold (0.88 log units), on the high side, outside the stated range (below it).
By their numbers in this assay, from the lowest: compound 4; then compound 1; then compounds 3 and 2 (each within the scatter of the next).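

In this assay, among these compounds, amino in place of bromo on an aromatic carbon, meta to a fused ring and para to a fused ring, gives a 4.2-fold lower number from compound 1 to compound 4 (0.63 log units; beyond the scatter), the first change that can be read on its own. This position of the shared core therefore does not depend on bromo for the effect, and it accepts an amino group, which counts one hydrogen-bond donor and one hydrogen-bond acceptor where bromo counts none. No measurement at hand bears on the origin of this step, so it stands as an observation on one pair only.

A single pair cannot separate the contribution of amino entering from that of bromo leaving: a dimethylamino group, an acetamide or a chlorine at the same carbon would help to divide the two. As far as these compounds go, it also remains open whether the step carries over when the other aromatic ring, with its own bromo and two methoxy groups, is changed, for example to a ring with a single fluorine.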